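The compounds below may be only part of what the source reports. "The series", "measured", "known", "first", "only" and "open" are said of these compounds alone.

Of the compounds shown here, three have so far been measured in a physicochemical assay for lipophilicity; a lower number here means a more polar compound, a higher number a more lipophilic compound. Compound 1 `C[C@H]1CC[C@@H]2[C@@H](OC(=O)[C@]23CC(c2ccc([N+](=O)[O-])cc2)=NO3)[C@]2(C)C(=O)C=C[C@@]12O` gives 1.37, and compound 2 `C[C@H]1CC[C@@H]2[C@@H](OC(=O)[C@]23CC(c2cccc([N+](=O)[O-])c2)=NO3)[C@]2(C)C(=O)C=C[C@@]12O` gives 1.37. Compound 3 `Cc1ccccc1C1C[C@@]2(ON1c1ccccc1)C(=O)O[C@@H]1[C@H]2CC[C@H](C)[C@]2(O)C=CC(=O)[C@@]12C` gives 3.64, the highest of the three numbers; its nearest neighbour is compound 1 and its furthest is compound 2, both lower by the same margin, beyond the scatter.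

Among the measured compounds shown here, the one measured step, no change at the digits printed from compound 1 to compound 2 (within the scatter), concerns a nitrophenyl group moved on a carbon with a double bond to nitrogen, a change of a different kind from the one now in question, so it offers no direct guide.

Compound 4 `COc1cccc(C2C[C@@]3(ON2c2ccccc2)C(=O)O[C@@H]2[C@H]3CC[C@H](C)[C@]3(O)C=CC(=O)[C@@]23C)c1` is the compound awaiting measurement. It differs from compound 3 in one place: 3-methoxyphenyl in place of 2-methylphenyl on a saturated ring carbon. For the measured compounds named here, no measured pair mirrors this swap, so the expectation rests on the value of compound 3, 3.64, as the starting point. Compound 4 is expected to lie somewhat below that, with an estimated step of a number 0.54 log units lower from compound 3 to compound 4 (beyond the scatter) in this assay. The estimate for compound 4 is therefore 3.1, with a range from 2.6 to 3.6.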

Compound 4, partition coefficient: 3.25
Estimate against measurement, compound 4: 0.15 log units below; low and high end bracket the measured number.
By their numbers in this assay, from the lowest: compounds 1 and 2 (each within the scatter of the next); then compound 4; then compound 3.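

On the saturated ring carbon next to the ring nitrogen, putting 3-methoxyphenyl in place of 2-methylphenyl gives a modest step in this assay: a number 0.39 log units lower from compound 3 to compound 4 (beyond the scatter). Among the compounds shown here, the only earlier step, which concerned a nitrophenyl group on a carbon with a double bond to nitrogen, showed no change at the digits printed from compound 1 to compound 2 (within the scatter), so this is the first measured exchange of groups that moves the number beyond the scatter. The entering group has 8 heavy atoms and 1 hydrogen-bond acceptor where the leaving group has 7 and 0, and the substituent and its number on the phenyl ring both differ, but no measurement at hand explains the lower number.

The compounds shown leave open how much of the step belongs to the methoxy group and how much to its location on the ring, a question that 3-methylphenyl or 2-methoxyphenyl on this same carbon would help to separate. They also leave open how this assay would respond to an amine or a carboxylic acid on the phenyl ring at this carbon.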